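The source may hold more compounds than are shown below. What is called first, only, known or untested is meant among the compounds shown, and "the series" means these compounds.

compound 1 `C=CCc1ccc(OCc2cn(-c3cccc([N+](=O)[O-])c3)nn2)c(O)c1`: 68.9%
compound 2 `C=CCc1ccc(OCc2cn(-c3ccc(C#N)cc3)nn2)c(O)c1`: 62.5%
compound 3 `C#CCOc1ccc(CC=C)cc1O`: 88.4%

All three values come from a functional assay on SK-N-SH cells (Homo sapiens) for inhibition, read by MTT assay, with a stated time of 72 h, tested at 50 uM (on this read-out higher numbers stand for more inhibition of growth at the one concentration tested and lower numbers for less inhibition of growth), and are compared on that read-out only. Compound 2 gives 62.5% and compound 1 gives 68.9%, and these two values lie within the scatter of each other. Compound 3 gives 88.4%. The gap between compound 2 and compound 3 lies beyond the scatter, with compound 3 the higher of the two.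

The next step leads to compound 4 (`C=CCc1ccc(OCc2cn(-c3ccccc3CO)nn2)c(O)c1`), with 2-(hydroxymethyl)phenyl in place of 4-cyanophenyl on an aromatic nitrogen. Among the measured compounds shown here, no pair of measured compounds differs in one place only, so the series gives no direct measure of such a change. For the measured compounds named here, the only guide is that compound 1 (68.9%) and compound 2 (62.5%) carry different groups on that nitrogen and stay within the scatter of each other. On that thin basis, no step beyond the scatter is expected in this assay (this assay), and no direction is favoured. The expected step is small (a number 0.5 percentage points lower from compound 2 to compound 4 (within the scatter)). Compound 4 is estimated at 62%, with an expected range from 45% to 78%.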

Compound 4, percent growth inhibition at one concentration: 87.1%
Estimate against measurement, compound 4: 25.1 percentage points below, and the stated range ends below it.
By their numbers in this assay, from the lowest: compounds 2 and 1 (each within the scatter of the next); then compounds 4 and 3 (each within the scatter of the next).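

In this assay, 2-(hydroxymethyl)phenyl in place of 4-cyanophenyl on the aromatic nitrogen gives a number 24.6 percentage points higher from compound 2 to compound 4 (beyond the scatter). Among the compounds shown here, this is the first single-place change, and it shows that the read-out can respond to the group on this nitrogen, which the earlier compounds could not show because no two of them differed in one place only. No measurement available here accounts for the step.

The compounds shown do not separate the contribution of the hydroxymethyl group from that of its place on the phenyl ring, since the nitrile and the substitution pattern change together in this step. From the compounds shown here alone, it also remains open how this position would respond to an amine or a carboxylic acid in place of the hydroxymethyl group, or to a longer chain ending in a hydroxyl.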